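The compounds below may be only part of what the source reports. "The series", "measured", "known", "first", "only" and "open" are said of these compounds alone.

Of the compounds shown here, two have been tested in a functional assay on the whole organism (Tail, strain ICR) with Mus musculus as the target, in the tail flick test, with a stated time of 60 min, at a dose of 25 umol/kg by the oral route; on this read-out lower numbers stand for a weaker effect and higher numbers for a stronger effect at the one dose given. Compound 1 `O=C(CN(c1ncnc2c1ncn2C1CCCCO1)C1CC1)NCC(=O)OCc1ccccc1` is one of them; in this assay compound 1 gives 40.4%. Compound 2 `CC(C)[C@H](NC(=O)CN(c1nc(Cl)nc2[nH]cnc12)C1CC1)C(=O)O` differs from it in more than one place; in this assay compound 2 gives 38.8%, a figure that lies within the usual scatter of the figure for compound 1, so the two compounds cannot be told apart on these numbers. For the measured compounds named here, no pair of measured compounds differs in a single place, so no measured step is available to calibrate the change about to be made.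

Compound 3 `N=C(N)NCCC[C@H](NC(=O)CN(c1ncnc2c1ncn2C1CCCCO1)C1CC1)C(=O)OCc1ccccc1` is the next compound and is still to be measured. It differs from compound 1 in one place: a group of 7 heavy atoms (4 carbon, 3 nitrogen; no ring) in place of a hydrogen atom, on a saturated chain carbon bound to an amide-type nitrogen and a carbonyl carbon. Going by the values given here, with no single-point step among the measured compounds to rest on, and with compound 1 and compound 2 giving figures within the scatter of each other despite differing in several places, the expected step, a number 0.4 percentage points lower from compound 1 to compound 3 (within the scatter), is small, with no clear direction beyond the scatter. Compound 3 is accordingly estimated at 40%, within a range from 20% to 60%.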

Compound 3, a percentage reported as activity, at one dose (the size of the read-out at that dose, not a potency): 52.4%
Compound 3: the middle estimate sits 12.4 percentage points below what was measured; the measured number falls inside the stated range.
By their numbers in this assay, from the lowest: compounds 2 and 1 (each within the scatter of the next); then compound 3.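

The saturated chain carbon bound to an amide-type nitrogen and a carbonyl carbon accepts substitution without loss of effect in this assay: a group of 7 heavy atoms (4 carbon, 3 nitrogen; no ring) in place of a hydrogen atom gives a number 12 percentage points higher from compound 1 to compound 3 (beyond the scatter). For the compounds shown here, this is the first single-place step, so this carbon is the one position where a change has a measured effect, and the step is modest and holds only for the one dose and time tested. Nothing shown bears on why the figure rises, and the step stands as an observation only.

On these data alone, it remains open whether the rise requires the whole group or would also appear with a simple methyl at this carbon, a shorter chain, or a primary amine at the end of a chain of the same length. Also open, as far as these compounds go, is whether the same group gives a similar step on the core of compound 2, or at other doses and times.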